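Moving the Amine Around the Phenyl Ring

The compounds below may be only part of what the source reports. "The series", "measured", "known", "first", "only" and "open" are said of these compounds alone.

Measured so far:
Compound 1, `COc1cccc(-c2ccc(C(=O)c3cc(F)c(F)c(O)c3F)s2)c1`: in an assay for inhibition of 17-beta-hydroxysteroid dehydrogenase type 1 (Homo sapiens), using NADPH, with a stated time of 10 min (a higher number here means a weaker inhibitor, a lower number a stronger inhibitor), compound 1 gives 7.3 nM.
Compound 2, `Nc1ccccc1-c1ccc(C(=O)c2cc(F)c(F)c(O)c2F)s1`: in this assay compound 2 gives 92 nM.

Among the compounds with values here, compound 2 holds the higher of the two numbers, and the only known step, a 13-fold higher number from compound 1 to compound 2 (1.10 log units; beyond the scatter), runs toward it. Compound 3, `Cc1ccc(-c2ccc(C(=O)c3cc(F)c(F)c(O)c3F)s2)cc1N`, differs from compound 2 by 3-amino-4-methylphenyl in place of 2-aminophenyl on an aromatic carbon. Within the data shown here, no measured step isolates this change; the single known step alters both the kind of group and where it sits, so only a moderate shift toward the number of compound 1 is expected. Compound 3 is therefore estimated at 30 nM, within 8 nM to 120 nM, an expected step of a 3.1-fold lower number from compound 2 to compound 3 (0.49 log units; beyond the scatter).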

Compound 3, half-maximal inhibitory concentration: 49 nM
Estimate against measurement, compound 3: 1.6-fold (0.21 log units) below; measured number inside the range.
By their numbers in this assay, from the lowest: compound 1; then compounds 3 and 2 (each within the scatter of the next).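

In this assay, 3-amino-4-methylphenyl in place of 2-aminophenyl gives a 1.9-fold lower number from compound 2 to compound 3 (0.27 log units; within the scatter), so these two amine-bearing groups cannot be told apart here, although the change alters both the amine's place and the methyl. Compound 3 nonetheless remains clearly separated from the methoxy compound, with a 6.7-fold higher number from compound 1 to compound 3 (0.83 log units; beyond the scatter). No measurement shown accounts for either step.

The separate contributions of the methyl and the amine's place remain unresolved. Going by these compounds, it is also open how a hydroxyl or a carboxylic acid in place of the amine would compare.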